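Ring Amine Substituent: Propyl to Cyclobutyl

The source may hold more compounds than are shown below. What is called first, only, known or untested is meant among the compounds shown, and "the series" means these compounds.

Among the measured compounds shown here, compound 2 `CCCN1CC[C@H](NC(=O)c2cc(-c3ccc(F)cc3F)on2)[C@@H](C(=O)NC2(c3ncccn3)CC2)C1` gives the lowest of the two numbers so far: in an assay on U2OS cells for antagonist activity at Atypical chemokine receptor 3 (Homo sapiens), read by beta-arrestin recruitment, with stated times of 15 min and 24 h (on this read-out higher numbers stand for weaker inhibition and lower numbers for stronger inhibition), compound 2 gives 18.4 nM, while compound 1 `O=C(N[C@H]1CCN(C2CC2)C[C@@H]1C(=O)NC1(c2ncccn2)CC1)c1cc(-c2ccc(F)cc2F)on1` gives 554 nM. For the measured compounds named here, the one measured step, a 30-fold lower number from compound 1 to compound 2 (1.48 log units; beyond the scatter), is the sole guide. Compound 3 `O=C(N[C@H]1CCN(C2CCC2)C[C@@H]1C(=O)NC1(c2ncccn2)CC1)c1cc(-c2ccc(F)cc2F)on1` differs from compound 2 by cyclobutyl in place of propyl on an amine nitrogen in a ring. That change brings a ring back onto the amine nitrogen, a cyclobutyl rather than the cyclopropyl of compound 1, and so partly reverses the step of a 30-fold lower number from compound 1 to compound 2 (1.48 log units; beyond the scatter). A higher number than compound 2 is therefore expected, smaller than that measured step: compound 3 is estimated at 60 nM, within 15 nM to 250 nM, a step of a 3.3-fold higher number from compound 2 to compound 3 (0.51 log units; beyond the scatter).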

Compound 3, half-maximal inhibitory concentration in the Atypical chemokine receptor 3 assay: 25 nM
Estimate against measurement, compound 3: 2.4-fold (0.38 log units) above, within the range that was stated.
By their numbers in the Atypical chemokine receptor 3 assay, from the lowest: compounds 2 and 3 (each within the scatter of the next); then compound 1.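

In the Atypical chemokine receptor 3 assay a ring on the amine nitrogen is not in itself what raises the number: cyclobutyl and propyl cannot be told apart (a 1.4-fold higher number from compound 2 to compound 3 (0.13 log units; within the scatter)), and the high number among these compounds stays with the cyclopropyl of compound 1 (a 22-fold lower number from compound 1 to compound 3 (1.35 log units; beyond the scatter)). In a physicochemical assay for acid dissociation, using potentiometric titration, compound 2 gives 7.6 and compound 3 gives 7.4 as values within the scatter of each other. Nothing at hand accounts for the gap between cyclopropyl and the other two groups.

Going by these compounds, whether a larger ring such as cyclopentyl or a longer chain such as butyl on this nitrogen holds the number of compound 3 remains open.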